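This account rests on a few compounds, and the source may have more. Where it says the series, first, only, none or still open, it means among the compounds named here.

In a functional assay on DU-145 cells (Homo sapiens) for cytotoxicity, read by MTT assay, with a stated time of 48 h (on this read-out higher numbers stand for weaker inhibition and lower numbers for stronger inhibition), compound 1 (`CCn1c(/C=C2/C(=O)Nc3ccccc32)nc2ccccc21`) gives > 50000 nM, which is a limit of the assay and not a number. From the compounds shown here alone, the starting point is therefore (the limit of > 50000 nM in this assay, at which 1 of the 2 values shown sits), so the true value of compound 1 is unknown. Compound 2 (`CC(C)n1c(/C=C2/C(=O)Nc3ccccc32)nc2ccccc21`) gives 38100 nM, and it carries methyl in place of hydrogen on a saturated chain carbon bound to an aromatic nitrogen and a saturated chain carbon. Compound 3 (`CCn1c(/C=C2/C(=O)Nc3ccc(Br)cc32)nc2ccccc21`) changes a different part of compound 1, with bromo in place of hydrogen on an aromatic carbon of a six-membered aromatic ring of carbon only: bromo in place of hydrogen on an aromatic carbon. For the measured compounds named here, the only measured step, an at least 1.3-fold lower number from compound 1 to compound 2 (0.11 log units; that floor lies within the scatter), is the sole guide, and it does not involve bromo, so it offers only weak support. A modest move towards a lower number, meaning stronger inhibition, is expected, although a result that again reaches the limit of the assay would be no surprise. The expected change is an at least 1.6-fold lower number from compound 1 to compound 3 (0.22 log units; that floor lies within the scatter). For compound 3 the estimated value is 30000 nM, with an expected range from 10000 nM to 50000 nM.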

Compound 3, half-maximal inhibitory concentration: 45800 nM
Estimate against measurement, compound 3: 1.5-fold (0.18 log units) below, within the range that was stated.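

In this assay, compounds 1 and 2 differ only in the chain on the aromatic nitrogen, whereas compound 3 tests a change on a six-membered aromatic ring of carbon only, with bromo on a carbon that is meta to a fused ring and para to a fused ring. The step is an at least 1.0-fold lower number from compound 1 to compound 3 (0.03 log units; that floor lies within the scatter), so bromo at this place yields a number rather than a limit, but the data do not establish that it shifts the read-out. For compound 1 the value is a limit and not a number, so the true size of the step stays unknown, because the comparison starts from that limit: the limit of > 50000 nM in this assay, at which 1 of the 3 values shown sits.

The compounds shown leave open whether a different group on this same aromatic carbon, such as chloro, methoxy or an amine, would give a clearly lower number, and whether bromo on another carbon of that ring would read differently. They also leave open what bromo would do when combined with the extra methyl of compound 2, since no compound shown carries both changes.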